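The compounds below may be only part of what the source reports. "The series", "measured", "known", "first", "only" and "open" are said of these compounds alone.

The measured compounds and their values in an ADME assay on MT2 cells (Homo sapiens) for cytotoxicity, read by XTT assay, with a stated time of 4 days; on this read-out lower numbers stand for higher toxicity in this test and higher numbers for lower toxicity in this test:
compound 1 `Cc1cc(/C=C/C#N)cc(C)c1Oc1ccc([N+](=O)[O-])c(Nc2ccc(C#N)cc2)c1`, > 100000 nM;
compound 2 `CC(=O)/C=C/c1cc(C)c(Oc2cc(Nc3ccc(C#N)cc3)c([N+](=O)[O-])cc2[N+](=O)[O-])c(C)c1`, > 100000 nM;
compound 3 `Cc1cc(/C=C/C#N)cc(C)c1Oc1ccc(N)c(Nc2ccc(C#N)cc2)c1`, 8830 nM.

The value of compound 1 is a limit of this assay and not a number. The value of compound 2 is likewise a limit, so that (the limit of > 100000 nM in this assay, at which 2 of the 3 values shown sit). Compound 3 carries amino in place of nitro on an aromatic carbon, and this change gave an at least 11-fold lower number from compound 1 to compound 3 (1.05 log units; beyond the scatter). How the core of compound 2 differs from the core of compound 1 is not broken down here. Compound 4 `CC(=O)/C=C/c1cc(C)c(Oc2cc(Nc3ccc(C#N)cc3)c(N)cc2[N+](=O)[O-])c(C)c1` is not yet measured; it carries amino in place of nitro on an aromatic carbon, the same kind of change, here also meta to a nitro group. Compound 4 is expected to give 15000 nM, between 4000 nM and 80000 nM, which means an expected at least 6.6-fold lower number from compound 2 to compound 4 (0.82 log units; beyond the scatter) beside the measured step. This expectation rests on compound 3, whose value of 8830 nM followed the same kind of change.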

Compound 4, half-maximal cytotoxic concentration: 22600 nM
Compound 4: middle estimate off by 1.5-fold (0.18 log units), on the low side; low and high end bracket the measured number.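

In this assay, amino in place of nitro on an aromatic carbon again went with a lower number on a second core (an at least 4.4-fold lower number from compound 2 to compound 4 (0.64 log units; beyond the scatter)). The direction is thus the same on the two cores, but nothing can be said about whether the size carries over: the same change on two cores in this assay, an at least 11-fold lower number (1.05 log units; beyond the scatter) from compound 1 to compound 3 and an at least 4.4-fold lower number (0.64 log units; beyond the scatter) from compound 2 to compound 4; the limit leaves it open whether they differ. Compound 2 gives > 100000 nM, which is a limit of the assay and not a number, and the same holds for one other compound: the limit of > 100000 nM in this assay, at which 2 of the 4 values shown sit.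

The compounds shown leave open whether a methylamino or an acetamido group in that place would read like the amino group. They also leave open how a carboxylic acid there would read, and whether the change keeps its direction on any further core.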